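The source may report more compounds than this note shows. Statements on the series, on what has been measured and on what is new or still open speak of the compounds shown alone.

Compound 1 `Cc1ccc(S(=O)(=O)N[C@@H](CC(=O)NC(C)(C)C)C(=O)NCCNC(=O)c2ccc(F)cc2)cc1`: > 11000 nM
Compound 2 `Cc1ccc(S(=O)(=O)N[C@@H](CC(=O)NC(C)(C)C)C(=O)NCCNC(=O)c2cccc(F)c2)cc1`: > 11000 nM

In an ADME assay on HepG2 cells (Homo sapiens) for cytotoxicity (a higher number here means that more compound is needed for the effect, a lower number that less compound is needed), compound 2 gives > 11000 nM, which is a limit of the assay and not a number. Compound 1 gives > 11000 nM, also a limit. The two results share one limit: the limit of > 11000 nM in this assay, at which 2 of the 2 values shown sit. Among the measured compounds shown here, the only measured step is a step that the two limits leave unreadable from compound 1 to compound 2, so it offers no size to carry forward.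

Compound 3 `Cc1ccc(S(=O)(=O)N[C@@H](CC(=O)NC(C)(C)C)C(=O)NCCNS(=O)(=O)c2ccccc2)cc1` keeps the shared core and carries phenylsulfonyl in place of (3-fluorophenyl)carbonyl on an amine nitrogen. For the measured compounds named here, no measured step covers this change, and the only anchor is the limit of compound 2, > 11000 nM. In this assay, no shift beyond the scatter is therefore expected in either direction, and the expected step is a step that the limit leaves unreadable from compound 2 to compound 3. Compound 3 is estimated at 15000 nM. The estimated range for compound 3 runs from 6000 nM to 40000 nM.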

Compound 3, half-maximal effective concentration: > 11000 nM
Compound 3 gave a limit, no number (the forecaster's own chance of this, stated with the estimate: 85%); the middle value does not contradict the limit.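

Compound 1, compound 2 and compound 3 all stop at a limit and give no number, so no step among them can be read: the limit of > 11000 nM in this assay, at which 3 of the 3 values shown sit.

The compounds shown leave open how much of each is needed for the effect in this assay, and whether the three differ at all.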